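A few compounds are considered here, and "the series" means these few. Any claim that something is new, unique, unknown or untested is made for them only; others in the source may bear on it.

Measured so far in an assay for displacement of a labelled ligand from Sigma non-opioid intracellular receptor 1 (Cavia porcellus), read by scintillation counting, with a stated time of 180 min; on this read-out higher numbers stand for weaker inhibition and lower numbers for stronger inhibition:
Compound 1 `Cn1ncc2c1CCOC21CCN(N2CCC(c3ccccc3)CC2)CC1` gives 7 nM.
Compound 2 `COC1Cc2c(cnn2-c2ccccc2)C2(CCNCC2)O1` gives > 1000 nM, which is a limit of the assay and not a number.
Compound 3 `COC1Cc2c(cnn2-c2ccccc2)C2(CCN(CCCc3ccccc3)CC2)O1` gives 3.2 nM.

Compound 3 holds the lowest of the two numbers read in this assay; its nearest neighbour, compound 1, sits higher by a gap beyond the usual scatter, and the remaining value is only a limit. Compound 4 `COC1Cc2c(cnn2-c2ccccc2)C2(CCN(C(C)C)CC2)O1` differs from compound 3 in a single place: isopropyl in place of 3-phenylpropyl on an amine nitrogen in a ring. Among the compounds with values here, one measured step touches this same nitrogen: an at least 310-fold lower number from compound 2 to compound 3 (2.49 log units; beyond the scatter), a large change, with compound 2 sitting at the limit of > 1000 nM in this assay, at which 1 of the 3 values shown sits. That step says that a group on this ring nitrogen matters a great deal for the read-out, but it compares a bare nitrogen with a long aromatic chain, not a long chain with a short one. Compound 4 keeps a group there, yet a far smaller one, so part of the gain seen in that step is expected to be lost. The expected step is therefore a 47-fold higher number from compound 3 to compound 4 (1.67 log units; beyond the scatter), upward in number and so toward weaker inhibition, beyond the scatter. For compound 4 the estimated value is 150 nM, with a likely range from 20 nM to 1500 nM.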

Compound 4, inhibition constant: 210 nM
Beside the measured number, compound 4's estimate is 1.4-fold (0.15 log units) below it; low and high end bracket the measured number.
By their numbers in this assay, from the lowest: compound 3; then compound 1; then compound 4. At a limit, above all of these: compound 2.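

In this assay, isopropyl in place of hydrogen on the ring nitrogen gives an at least 4.7-fold lower number from compound 2 to compound 4 (0.67 log units; beyond the scatter), so even a small group on this nitrogen strengthens inhibition compared with the bare nitrogen. Compound 2 is read only at a limit and not a number, so this step has no exact size: the limit of > 1000 nM in this assay, at which 1 of the 4 values shown sits.

The presence of a group is not the whole story, however: going to the shorter group gives a 66-fold higher number from compound 3 to compound 4 (1.82 log units; beyond the scatter), which shows that the kind of group on this nitrogen matters as well, and that isopropyl does not hold the strong inhibition seen with 3-phenylpropyl.

That change removes chain length and the six-membered aromatic ring together, so the compounds shown cannot tell which of the two accounts for the difference. On these data alone, it remains open whether a plain butyl chain with no ring would keep the low number of compound 3, or whether a benzyl or 2-phenylethyl group, each with the ring on a shorter chain, would do so.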